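The source may hold more compounds than are shown below. What is called first, only, known or untested is meant among the compounds shown, and "the series" means these compounds.

- Compound 1 `COc1ccc(/C=C2\c3cc(OC)c(OC)c(OC)c3CC[C@@H]2O)cc1C#N`: 20 nM
- Compound 2 `COc1ccc(/C=C2\c3cc(OC)c(OC)c(OC)c3CC[C@@H]2O)cc1O`: 1060 nM
- Compound 3 `COc1ccc(/C=C2\c3cc(OC)c(OC)c(OC)c3CC[C@@H]2O)cc1[N+](=O)[O-]`: 4640 nM

These values come from a functional assay on SK-OV-3 cells (Homo sapiens) for inhibition, read by MTT assay; a lower number here means a stronger inhibitor, a higher number a weaker inhibitor. Compound 3 has the highest number of the three, which makes it the weakest inhibitor here, with its steps to both others beyond the scatter. Compound 4 `COc1ccc(/C=C2\c3cc(OC)c(OC)c(OC)c3CC[C@@H]2O)cc1C` changes one group: methyl in place of nitro on an aromatic carbon. Going by the values given here, no measured compound carries methyl, so only the swaps at this same place bear on it. There, a 230-fold higher number from compound 1 to compound 3 (2.37 log units; beyond the scatter) is large and a 4.4-fold higher number from compound 2 to compound 3 (0.64 log units; beyond the scatter) is modest. This place clearly matters, and compound 3 sits at the weak end, so a moderate step towards a lower number is expected, though not all the way to compound 1. The expected change is a 9.3-fold lower number from compound 3 to compound 4 (0.97 log units; beyond the scatter). For compound 4 the estimate is 500 nM, with an expected range of 80 nM to 3000 nM.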

Compound 4, half-maximal inhibitory concentration: 730 nM
Compound 4: the middle estimate sits 1.5-fold (0.16 log units) below what was measured, and the stated range covers the measured number.
By their numbers in this assay, from the lowest: compound 1; then compounds 4 and 2 (each within the scatter of the next); then compound 3.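

Methyl, a single carbon with no hydrogen-bond acceptors, does better than nitro in this assay with a 6.4-fold lower number from compound 3 to compound 4 (0.80 log units; beyond the scatter) but falls far short of the nitrile with a 37-fold higher number from compound 1 to compound 4 (1.56 log units; beyond the scatter) at this same place. Against hydroxy there is a 1.5-fold lower number from compound 2 to compound 4 (0.16 log units; within the scatter) and so no order between the two, which leaves the nitrile as the only one of these four groups giving a strong inhibitor. No other measurement is at hand to explain these steps.

As far as these compounds go, whether the nitrile's lead is unique to it stays open, since an amine, a fluorine atom or an ethynyl group at this place could test that. The compounds shown also leave open whether these steps hold in other cell lines.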